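Thiophene for Furan on a Saturated Ring Carbon

The compounds below may be only part of what the source reports. "The series", "measured", "known", "first", "only" and "open" are said of these compounds alone.

Three compounds have numbers in a functional assay on Ehrlich cells (Mus musculus) for antiproliferative activity, read by trypan blue exclusion, with a stated time of 2 h, tested at 25 ug/mL; a lower number here means a weaker effect, a higher number a stronger effect of the compound at the concentration tested:
compound 1, `N#CC1=C(N)N(c2ccc(S(N)(=O)=O)cc2)C2=C(C(=O)CCC2)C1/C=C/c1ccccc1`, gives 10%
compound 2, `COc1cc(CC2C(C#N)=C(N)N(c3ccc(S(N)(=O)=O)cc3)C3=C2C(=O)CCC3)ccc1O`, gives 50%
compound 3, `N#CC1=C(N)N(c2ccc(S(N)(=O)=O)cc2)C2=C(C(=O)CCC2)C1c1ccco1`, gives 0%

Compound 3 has the lowest of the three numbers. Its nearest neighbour is compound 1, and the step of a number 10 percentage points lower from compound 1 to compound 3 (within the scatter) stays within the scatter, so the two cannot be ranked against each other. Its furthest neighbour is compound 2, and the step of a number 50 percentage points lower from compound 2 to compound 3 (beyond the scatter) is large and beyond the scatter; the step of a number 40 percentage points higher from compound 1 to compound 2 (beyond the scatter) is the only other large one seen.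

Compound 4, `N#CC1=C(N)N(c2ccc(S(N)(=O)=O)cc2)C2=C(C(=O)CCC2)C1c1cccs1`, differs from compound 3 in one place: thiophen-2-yl in place of furan-2-yl on a saturated ring carbon. Among the measured compounds shown here, no measured step exchanges one five-membered aromatic ring with one hetero atom for another; the two steps that lead to compound 3 remove larger groups. Neither gives grounds to expect a step beyond the scatter, so compound 4 is expected to show a number 10 percentage points higher from compound 3 to compound 4 (within the scatter). The estimate for compound 4 in this assay is 10%, with a range from 0% to 30%.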

Compound 4, a percentage reported as activity, at one concentration (the size of the read-out at that concentration, not a potency): 80%
The estimate for compound 4 lay 70 percentage points below the measured number; the measured number lies above the stated range.
By their numbers in this assay, from the lowest: compounds 3 and 1 (each within the scatter of the next); then compound 2; then compound 4.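

In this assay this position proves sensitive to the hetero atom alone: thiophen-2-yl and furan-2-yl match in heavy atoms, ring type, donors and acceptors, and differ only in sulfur for oxygen, yet the exchange gives a number 80 percentage points higher from compound 3 to compound 4 (beyond the scatter) on this saturated ring carbon. A five-membered ring here can therefore also surpass both larger groups, with a number 30 percentage points higher from compound 2 to compound 4 (beyond the scatter) and a number 70 percentage points higher from compound 1 to compound 4 (beyond the scatter) as the steps, leaving compound 4 the highest of the four. Nothing at hand explains why sulfur and oxygen part so widely at this position.

As far as these compounds go, whether the gain carries over to thiophen-3-yl, to pyrrol-2-yl with nitrogen as its hetero atom, or to a plain phenyl on the same carbon stays open. So does how compound 4 would read at other concentrations.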